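The source may report more compounds than this note shows. Statements on the series, on what has been measured and on what is new or still open speak of the compounds shown alone.

Compounds measured so far, in an assay on CHO cells for displacement of a labelled ligand from adenosine receptor A1 (Homo sapiens), read by scintillation counting, with a stated time of 120 min, tested at 10 uM; a lower number here means less inhibition, a higher number more inhibition at the concentration tested (going by the name of the read-out):
compound 1, `Nc1scc(CN2CCN(c3ccc(C(F)(F)F)cc3)CC2)c1C(=O)c1cccc(C(F)(F)F)c1`: compound 1 gives 0%
compound 2, `Nc1scc(CN2CCN(c3c(F)cccc3F)CC2)c1C(=O)c1cccc(C(F)(F)F)c1`: compound 2 gives 0%
compound 3, `Nc1scc(CN2CCN(c3cccc4ccccc34)CC2)c1C(=O)c1ccc(Cl)cc1`: compound 3 gives 1%

Compound 3 sits within the scatter of compound 1 and of compound 2; none of the three shows inhibition beyond the scatter in this assay. Among the measured compounds shown here, the only one-place step recorded, the change on the amine nitrogen in a ring from compound 1 to compound 2, gave no change at the digits printed from compound 1 to compound 2 (within the scatter). Compound 4, `Nc1scc(CN2CCN(c3cc(Cl)ccc3Cl)CC2)c1C(=O)c1ccc(Cl)cc1`, differs from compound 3 by 2,5-dichlorophenyl in place of naphthalen-1-yl on an amine nitrogen in a ring, again a swap of the aryl group on that ring nitrogen. For the measured compounds named here, the one step of that kind bearing on it was flat, so no step beyond the scatter is expected in this assay. For compound 4 the estimated step is no change at the digits printed from compound 3 to compound 4 (within the scatter) and the expected value is 1%, between -6% and 9%.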

Compound 4, a percentage reported as inhibition, at one concentration (the size of the read-out at that concentration, not a potency): 0%
Beside the measured number, compound 4's estimate is 1 percentage points above it; the measured number falls inside the stated range.
By their numbers in this assay, from the lowest: compounds 1, 2, 4 and 3 (each within the scatter of the next).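

In this assay, 2,5-dichlorophenyl in place of naphthalen-1-yl on an amine nitrogen in a ring gives a number 1 percentage points lower from compound 3 to compound 4 (within the scatter) on the shared core. The earlier step at this position joined two single-ring aryl groups, whereas this one also goes from two six-membered aromatic rings to one and brings in two chlorine atoms, and the read-out still stays within the scatter. No measurement available accounts for this flat result.

From the compounds shown here alone, whether a non-aryl group on this ring nitrogen, such as benzyl or a longer alkyl chain, would move the read-out remains open. Also open, going by these compounds, is whether any change elsewhere on the core would.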